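A few compounds are considered here, and "the series" means these few. Any claim that something is new, unique, unknown or untested is made for them only; others in the source may bear on it.

Compound 1 `COc1ccc(NC(=O)Nc2nc(Sc3c[nH]c4ccccc34)cc(N3CCN(Cc4ccccc4)CC3)n2)cc1`: 42300 nM
Compound 2 `COc1ccc(NC(=O)Nc2nc(Sc3c[nH]c4ccccc34)cc(N3CCCCC3)n2)cc1`: 13500 nM
Compound 3 `COc1cc(NC(=O)Nc2nc(Nc3cc(OC)cc(OC)c3)cc(Sc3c[nH]c4ccccc34)n2)cc(OC)c1`: > 50000 nM

All three compounds were tested in a functional assay on A549 cells (Homo sapiens) for inhibition, with a stated time of 72 h; on this read-out lower numbers stand for stronger inhibition and higher numbers for weaker inhibition. Compound 1 and compound 2 both carry a 4-methoxyphenyl group on the urea nitrogen and both return a measured number: compound 1 gives 42300 nM and compound 2 gives 13500 nM. Compound 3 stands differently. For compound 3 this assay reports only > 50000 nM, which is a limit of the assay and not a measured number. This is the limit of > 50000 nM in this assay, at which 1 of the 3 values shown sits, so of the three compounds compound 3 is the one whose activity is known least precisely.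

Compound 4 `COc1ccc(NC(=O)Nc2nc(Nc3cc(OC)cc(OC)c3)cc(Sc3c[nH]c4ccccc34)n2)cc1` is the compound not yet measured. It differs from compound 3 in a single place: 4-methoxyphenyl in place of 3,5-dimethoxyphenyl on an amide-type nitrogen. After this change compound 4 carries the same 4-methoxyphenyl group on the urea nitrogen as compound 1 and compound 2, while keeping the rest of compound 3 unchanged.

For the measured compounds named here, no measured pair of compounds shows exactly this exchange, so the size of the step can only be guessed. A step toward stronger inhibition of modest size is expected in this assay, chiefly because compound 2 gives 13500 nM and compound 1 gives 42300 nM with the same 4-methoxyphenyl group in place. Compound 4 is therefore estimated at about 40000 nM, with a range from 10000 nM to 150000 nM. The expected step of an at least 1.2-fold lower number from compound 3 to compound 4 (0.09 log units; that floor lies within the scatter) is small, and a result that again stops at the limit of the assay remains quite possible.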

Compound 4, half-maximal inhibitory concentration: > 50000 nM
Compound 4: only a limit was reported; the forecaster's own chance of this, stated with the estimate: 45%; middle value at least 1.2-fold (0.09 log units) away from the limit.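

In this assay, the exchange of 3,5-dimethoxyphenyl for 4-methoxyphenyl on the amide-type nitrogen still yields no measured number, as compound 4 gives > 50000 nM, which is a limit of the assay. The size of the step between compound 3 and compound 4 therefore cannot be read, because both compounds stop at the same limit: the limit of > 50000 nM in this assay, at which 2 of the 4 values shown sit. What the new result does add concerns the group on the aromatic carbon: with 4-methoxyphenyl on the amide-type nitrogen in both compounds, (3,5-dimethoxyphenyl)amino in place of piperidin-1-yl gives an at least 3.7-fold higher number from compound 2 to compound 4 (0.56 log units; beyond the scatter), a change beyond the usual scatter, so this exchange weakens inhibition by at least that amount.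

On these data alone, it remains open whether the group on the amide-type nitrogen has any effect on inhibition, since a real difference between these two groups could lie hidden beyond the limit of the assay. As far as these compounds go, it is also open whether a morpholin-4-yl group or a small amine such as dimethylamino on the aromatic carbon would match piperidin-1-yl or give stronger inhibition.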